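The compounds below may be only part of what the source reports. "The series", "measured", "known", "first", "only" and "open" are said of these compounds alone.

Working notes on the ester side chain of the shared core. In a functional assay on RAW264.7 cells (Mus musculus) for inhibition, read by ELISA, with a stated time of 24 h (a lower number here means that less compound is needed, a higher number that more compound is needed for the effect), compound 1 (`CC/C=C\C[C@H]1C(=O)C=C[C@H]1CC(=O)OCCC`) gives 23000 nM, compound 2 (`CC/C=C\C[C@H]1C(=O)C=C[C@H]1CC(=O)OCCCCC`) gives 25000 nM and compound 3 (`CC/C=C\C[C@H]1C(=O)C=C[C@H]1CC(=O)OCCO`) gives 24000 nM. Compound 3 therefore stands level with the other two, within the scatter of both.

Compound 4 (`CC/C=C\C[C@H]1C(=O)C=C[C@H]1CC(=O)OCCOCCOC`) differs from compound 3 by a single change: 2-methoxyethyl in place of hydrogen on an oxygen on a saturated carbon.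

For the measured compounds named here, the steps that bear on this are the three other changes on the same saturated chain: a 1.1-fold higher number from compound 1 to compound 2 (0.04 log units; within the scatter), a 1.0-fold higher number from compound 1 to compound 3 (0.02 log units; within the scatter) and a 1.0-fold lower number from compound 2 to compound 3 (0.02 log units; within the scatter). All three lie within the scatter. Going by the values given here, no measured compound carries the 2-methoxyethyl group, so the expectation is an extrapolation from these steps.

No step beyond the scatter is expected in this assay, and no direction is favoured. The expected step is no change at the digits printed from compound 3 to compound 4 (within the scatter). Compound 4 is estimated at 24000 nM, with an expected range of 12000 nM to 50000 nM.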

Compound 4, half-maximal effective concentration: 33000 nM
Estimate against measurement, compound 4: 1.4-fold (0.14 log units) below, within the range that was stated.
By their numbers in this assay, from the lowest: compounds 1, 3, 2 and 4 (each within the scatter of the next).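

Putting 2-methoxyethyl on the terminal oxygen of compound 3 leaves the number in this assay within the scatter, with a 1.4-fold higher number from compound 3 to compound 4 (0.14 log units; within the scatter). The same holds against the two plain alkyl esters, with a 1.3-fold higher number from compound 2 to compound 4 (0.12 log units; within the scatter) and a 1.4-fold higher number from compound 1 to compound 4 (0.16 log units; within the scatter). Across these four compounds, the chain end therefore accepts a free hydroxy, simple alkyl ends and the 2-methoxyethoxy group without a step beyond the scatter, and this extends the earlier picture to a side chain with an ether oxygen added. Nothing available bears on the reason for this.

Going by these compounds, it remains open whether an amine or a carboxylic acid at the chain end would give a step beyond the scatter. The same question stands for a longer chain of repeating ethoxy units or an amide in place of the ester.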